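Swapping a Methoxy for a Dimethylamino on a Sulfonamide Chain

This account rests on a few compounds, and the source may have more. Where it says the series, first, only, none or still open, it means among the compounds named here.

Three compounds have been measured in an assay on CHO cells for displacement of a labelled ligand from prostaglandin D2 receptor 2 (Homo sapiens), read by scintillation counting; a higher number here means a weaker inhibitor, a lower number a stronger inhibitor:
Compound 1 `CS(=O)(=O)Cc1cccc(C#Cc2cc(Cl)ccc2OCC(=O)O)c1` gives 48 nM.
Compound 2 `COCCN(C)S(=O)(=O)c1ccc(C)c(C#Cc2cc(Cl)ccc2OCC(=O)O)c1` gives 4.1 nM.
Compound 3 `CCCc1ccncc1C#Cc1cc(Cl)ccc1OCC(=O)O` gives 4.3 nM.

Compound 2 has the lowest of the three numbers. Compound 3 sits within the scatter of it, so the two cannot be ranked. Compound 1 lies beyond the scatter, with a clearly higher number. Compound 4 `Cc1ccc(S(=O)(=O)N(C)CCCN(C)C)cc1C#Cc1cc(Cl)ccc1OCC(=O)O` differs from compound 2 in one place: (dimethylamino)methyl in place of methoxy on a saturated chain carbon, two bonds along the chain from a sulfonamide nitrogen. Among the measured compounds shown here, no measured pair shows this change, so there is no step to lean on. The sulfonamide and the shared core stay untouched, and the expected step is a 1.5-fold higher number from compound 2 to compound 4 (0.17 log units; within the scatter), within the scatter. Compound 4 is estimated at 6 nM in this assay, with a range of 2 nM to 20 nM.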

Compound 4, inhibition constant: 287 nM
Compound 4: middle estimate off by 48-fold (1.68 log units), on the low side; the whole stated range lies below it.
By their numbers in this assay, from the lowest: compounds 2 and 3 (each within the scatter of the next); then compound 1; then compound 4.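

This position on the sulfonamide chain is far from indifferent to what it carries: in this assay, (dimethylamino)methyl in place of methoxy gives a 70-fold higher number from compound 2 to compound 4 (1.85 log units; beyond the scatter) and so a much weaker inhibitor. The sulfonamide and the shared core stay untouched, so this single change in the chain accounts for the whole step. Nothing measured here says why the number rises so far.

A 3-methoxypropyl chain would separate the effect of the longer chain from that of the amine, and that comparison stands open. As far as these compounds go, whether a hydroxyl or a carboxylic acid at the chain end would be tolerated also stays unknown.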